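This account rests on a few compounds, and the source may have more. Where it says the series, first, only, none or still open, it means among the compounds named here.

Measured so far:
- compound 1 `CSCC[C@H](NC(=O)c1ccc(/C=C/c2cncs2)cc1-c1ccccc1C)C(=O)O`: > 1000 nM
- compound 2 `CSCC[C@H](NC(=O)c1ccc(/C=C/c2cncc(Cc3ccccc3)c2)cc1-c1ccccc1C)C(=O)O`: > 1000 nM
- compound 3 `CSCC[C@H](NC(=O)c1ccc(/C=C/c2cnccc2C(=O)c2ccccc2)cc1-c1ccccc1C)C(=O)O`: 1000 nM

All three values come from a functional assay on NIH3T3 cells (Mus musculus) for inhibition; a higher number here means that more compound is needed for the effect, a lower number that less compound is needed. Compound 1 gives > 1000 nM, which is a limit and not a number. Compound 2 gives > 1000 nM, which is also a limit. Compound 1 therefore stands at the limit of > 1000 nM in this assay, at which 2 of the 3 values shown sit. For the measured compounds named here, compound 3 gives 1000 nM, the only true number in the set.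

The next compound to be tested in this assay is compound 4 `CSCC[C@H](NC(=O)c1ccc(CCc2c[nH]cn2)cc1-c1ccccc1C)C(=O)O`. It carries 2-(1H-imidazol-4-yl)ethyl in place of the 2-(1,3-thiazol-5-yl)ethenyl of compound 1, on an aromatic carbon of the shared core: 2-(1H-imidazol-4-yl)ethyl in place of 2-(1,3-thiazol-5-yl)ethenyl on an aromatic carbon.

Going by the values given here, no measured pair differs in one place only, so there is no direct guide to the effect of this change. The expectation rests on the three values alone, and none of them points to a clear move in either direction. Compound 3, at 1000 nM, is the nearest numerical anchor. The expected step is a number no higher from compound 1 to compound 4 (the limit leaves the size open), with no change beyond the scatter anticipated. A further limit instead of a number would not be surprising. For compound 4 the estimated value is 1000 nM, with an expected range of 200 nM to 5000 nM.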

Compound 4, half-maximal effective concentration: > 1000 nM
Compound 4 ended at the assay's limit; the forecaster's own chance of this, stated with the estimate: 50%; the middle value lies on the limit itself.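

For the compounds shown here, compound 1 and compound 4 both stand at a limit, not a number, in this assay, so no step between them can be read: the limit of > 1000 nM in this assay, at which 3 of the 4 values shown sit. The compounds shown leave open whether 2-(1H-imidazol-4-yl)ethyl in place of 2-(1,3-thiazol-5-yl)ethenyl changes the effect at all, and in which direction.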